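An isomer of compound 1 in a clearance assay

This account rests on a few compounds, and the source may have more. Where it says the series, first, only, none or still open, it means among the compounds named here.

In an ADME assay on microsomes from liver (Mus musculus) for pharmacokinetics, read by LC-MS, using NADPH, with stated times of 5 min, 15 min and 30 min, tested at 10 uM (on this read-out higher numbers stand for fast clearance and lower numbers for slow clearance), compound 1 `C[C@H](NC(=O)c1cccc(F)c1)c1ccc(NC(=O)N2CC(c3ccc(N)nc3)C2)cc1` gives < 25 mL.min-1.g-1, which is a limit and not a number. In this assay compound 2 `C[C@H](NC(=O)[C@@H]1CCCN1C)c1ccc(NC(=O)N2CC(c3ccc(N)nc3)C2)cc1` gives < 25 mL.min-1.g-1, which is also a limit. Compound 1 therefore has no exact position, only (the limit of < 25 mL.min-1.g-1 in this assay, at which 2 of the 2 values shown sit).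

Compound 3 `C[C@H](NC(=O)c1cccc(F)c1)c1ccc(NC(=O)N2CC(c3cncc(N)c3)C2)cc1` has the same atoms as compound 1, joined differently: 5-aminopyridin-3-yl in place of 6-aminopyridin-3-yl on a saturated ring carbon. The change lies on a saturated ring carbon of a four-membered non-aromatic ring with 1 nitrogen.

Going by the values given here, the only measured step, a step that the two limits leave unreadable from compound 1 to compound 2, has little bearing on this change. It swaps a different group, on a carbonyl carbon, and its size cannot be read. Among the compounds with values here, no measured step sets a size for moving from 6-aminopyridin-3-yl to 5-aminopyridin-3-yl. The expectation therefore rests on compound 1 and its limit of < 25 mL.min-1.g-1. With no evidence favouring either direction, the expected step is a step that the limit leaves unreadable from compound 1 to compound 3, and no change beyond the usual scatter is expected. For compound 3 the estimate is 20 mL.min-1.g-1, with an expected range from 10 mL.min-1.g-1 to 50 mL.min-1.g-1.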

Compound 3, intrinsic clearance in microsomes: 27.4 mL.min-1.g-1
Estimate against measurement, compound 3: 1.4-fold (0.14 log units) below, and the stated range covers the measured number.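

Exchanging 6-aminopyridin-3-yl for 5-aminopyridin-3-yl on the saturated ring carbon gives an at least 1.0-fold higher number from compound 1 to compound 3 (0.03 log units; that floor lies within the scatter). This step has only a floor, so the swap shows no change beyond the scatter, yet it does not fix the true size of the step either. In this assay, compound 3 gives the only exact number among the compounds shown, while compound 1 and compound 2 each stop at a limit: the limit of < 25 mL.min-1.g-1 in this assay, at which 2 of the 3 values shown sit.

On these data alone, the exact distance between compound 1 and compound 3 stays open, and the step from compound 1 to compound 2 cannot be read, since both of its ends are limits. It also remains open how clearance would respond to a quite different group on this saturated ring carbon, such as a carboxylic acid or a longer alkyl chain in place of the aminopyridine, since the two aminopyridines shown here say nothing about such groups.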